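Working notes on two methyl additions in one antiproliferative series

This account rests on a few compounds, and the source may have more. Where it says the series, first, only, none or still open, it means among the compounds named here.

Measured compounds in a functional assay on A2780 cells (Homo sapiens) for antiproliferative activity, read by MTT assay, with a stated time of 48 h; a lower number here means a stronger inhibitor, a higher number a weaker inhibitor:
compound 1, `COc1ccc(-c2cc3c(cn2)[nH]c(=O)n3-c2cc(OC)c(OC)c(OC)c2)cc1F`, gives 730 nM.
compound 2, `CCOc1ccc(-c2cc3c(cn2)[nH]c(=O)n3-c2cc(OC)c(OC)c(OC)c2)cc1F`, gives 4330 nM.
compound 3, `CCn1c(=O)n(-c2cc(OC)c(OC)c(OC)c2)c2cc(-c3ccc(OC)c(O)c3)ncc21`, gives > 20000 nM, which is a limit of this assay and not a number.

The change from compound 1 to compound 2 is methyl in place of hydrogen on a saturated chain carbon bound to an oxygen on an aromatic ring. It made a 5.9-fold higher number from compound 1 to compound 2 (0.77 log units; beyond the scatter). Compound 3 carries a different core from compound 1; the difference between the two cores is not broken down here. Among the three values, (the limit of > 20000 nM in this assay, at which 1 of the 3 values shown sits), so one of them gives only a bound.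

Compound 4, `COc1ccc(-c2cc3c(cn2)n(C(C)C)c(=O)n3-c2cc(OC)c(OC)c(OC)c2)cc1O`, is not yet measured in this assay. It differs from compound 3 by methyl in place of hydrogen on a saturated chain carbon bound to an aromatic nitrogen and a saturated chain carbon. This is the same kind of change as from compound 1 to compound 2, but not the same: there the methyl entered on a saturated chain carbon bound to an oxygen on an aromatic ring, here it enters on a saturated chain carbon bound to an aromatic nitrogen and a saturated chain carbon.

Among the compounds with values here, for compound 4 the step is expected to be a step that the limit leaves unreadable from compound 3 to compound 4, and this rests on the earlier step, which made a 5.9-fold higher number from compound 1 to compound 2 (0.77 log units; beyond the scatter), the only measured step of this kind. Compound 4 is therefore expected at 40000 nM, most likely reported again as a limit of this assay. The expected range for compound 4 runs from 12000 nM to 150000 nM.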

Compound 4, half-maximal inhibitory concentration: 3160 nM
Estimate against measurement, compound 4: 13-fold (1.10 log units) above; measured number below the stated range.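

In this assay, methyl in place of hydrogen on a saturated chain carbon bound to an aromatic nitrogen and a saturated chain carbon, read as ethyl to isopropyl, gave an at least 6.3-fold lower number from compound 3 to compound 4 (0.80 log units; beyond the scatter). The direction of this methyl addition therefore did not carry from one core to the other in this series, and the two steps stand apart: the same change on two cores in this assay, a 5.9-fold higher number (0.77 log units; beyond the scatter) from compound 1 to compound 2 and an at least 6.3-fold lower number (0.80 log units; beyond the scatter) from compound 3 to compound 4, at least 37-fold (1.57 log units) apart, beyond the scatter of two such steps The two steps differ both in core and in the place of the methyl, so these two pairs cannot show whether the core or the place decides the outcome, and they set no rule for any further core.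

As far as these compounds go, compound 3 gives > 20000 nM, which is a limit of the assay and not a number, so the full size of the step remains open: the limit of > 20000 nM in this assay, at which 1 of the 4 values shown sits. Also open is how a longer chain, such as butyl, or a chain ending in an amine would read on the aromatic nitrogen, and whether the same ethyl to isopropyl change would follow the same direction with the rest of compound 3 held constant on another core.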